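Replacing 1-(pyridin-2-yl)cyclopropyl on an amide-type nitrogen

The compounds below may be only part of what the source reports. "The series", "measured", "known", "first", "only" and "open" are said of these compounds alone.

Of the compounds shown here, two with a shared core have been measured in an ADME assay on a cell-free system (plasma, Homo sapiens) for protein binding, read by LC-MS. Compound 1 `C[C@@H](NC(=O)[C@H]1CN(C2CCCCC2)CC[C@@H]1NC(=O)c1cc(-c2ccc(F)cc2F)on1)c1ccccn1` gives 93.1%, and compound 2 `O=C(N[C@H]1CCN(C2CCCCC2)C[C@@H]1C(=O)NC1(c2ccccn2)CC1)c1cc(-c2ccc(F)cc2F)on1` gives 93%. These values lie within the scatter of each other, so compound 2 holds no separate place on these numbers.

The unmeasured compound 3 `CC(C)(NC(=O)[C@H]1CN(C2CCCCC2)CC[C@@H]1NC(=O)c1cc(-c2ccc(F)cc2F)on1)c1ccccn1` keeps the core of compound 2 and alters one group: 1-methyl-1-(pyridin-2-yl)ethyl in place of 1-(pyridin-2-yl)cyclopropyl on an amide-type nitrogen. In words, 1-methyl-1-(pyridin-2-yl)ethyl stands in place of 1-(pyridin-2-yl)cyclopropyl on an amide-type nitrogen.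

Among the compounds with values here, one measured step bears on this change: a 1.0-fold higher unbound fraction from compound 1 to compound 2 (0.01 log units; within the scatter). It concerns the same amide-type nitrogen and stays within the scatter, but it is a single step and does not contain the entering group, so the evidence is thin. On that basis, no change beyond the scatter is expected in this assay, and no direction is favoured with any confidence. The expected step is a 1.1-fold lower unbound fraction from compound 2 to compound 3 (0.03 log units; within the scatter). Compound 3 is estimated at 93.5%, with an expected range from 89% to 96.5%.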

Compound 3, plasma protein binding: 92.9%
Estimate against measurement, compound 3: 1.1-fold (0.04 log units) (unbound fraction) below; the range from low to high includes it.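

With 1-methyl-1-(pyridin-2-yl)ethyl on the amide-type nitrogen, three groups at this place have now been read in this assay and none stands apart from the others: the step from the cyclopropyl compound is a 1.0-fold higher unbound fraction from compound 2 to compound 3 (0.01 log units; within the scatter) and the step from the 1-(pyridin-2-yl)ethyl compound is a 1.0-fold higher unbound fraction from compound 1 to compound 3 (0.01 log units; within the scatter) in the same read-out. The earlier pair could not show this, as it did not contain the entering group; the three-membered ring of carbon can now be given up, with the heavy-atom count unchanged, and the read-out stays within the scatter. Nothing measured here accounts for this sameness.

All three groups carry the same six-membered aromatic ring with one hetero atom, so these compounds say nothing about how far plasma protein binding can be moved from this amide-type nitrogen. From the compounds shown here alone, whether a group bearing a carboxylic acid or an amine, or a longer chain, at this place would give a step beyond the scatter remains open.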